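Carbamate and urea variation on the shared core

The source may hold more compounds than are shown below. What is called first, only, known or untested is meant among the compounds shown, and "the series" means these compounds.

Measured so far in a functional assay on A549 cells (Homo sapiens) for cytotoxicity, read by MTT assay; on this read-out lower numbers stand for stronger inhibition and higher numbers for weaker inhibition:
- compound 1, `CCc1cc(S(=O)(=O)N2C[C@H](c3ccccc3)NC2=O)ccc1NC(=O)c1ccc(N)cc1`, gives 220 nM
- compound 2, `CCc1cc(S(=O)(=O)N2C[C@H](c3ccccc3)NC2=O)ccc1NC(=O)OC(C)C`, gives 60 nM
- compound 3, `CCc1cc(S(=O)(=O)N2C[C@H](c3ccccc3)NC2=O)ccc1NC(=O)NC(C)C`, gives 100 nM

Compound 3 holds the second highest of the three numbers. Its nearest neighbour is compound 2, and the step of a 1.7-fold higher number from compound 2 to compound 3 (0.22 log units; within the scatter) lies within the scatter, so the two are not separable. Against compound 1 the picture is clearer: a 2.2-fold lower number from compound 1 to compound 3 (0.34 log units; beyond the scatter), and for the parallel comparison a 3.7-fold lower number from compound 1 to compound 2 (0.56 log units; beyond the scatter). Both replacements of 4-aminophenyl on the carbonyl carbon gave a lower number.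

Compound 4 is `CCc1cc(S(=O)(=O)N2C[C@H](c3ccccc3)NC2=O)ccc1NC(=O)OCC(C)C`. The change from compound 3 is isobutoxy in place of isopropylamino on a carbonyl carbon. Among the measured compounds shown here, only one measured step bears on it directly: a 1.7-fold higher number from compound 2 to compound 3 (0.22 log units; within the scatter), which covers the swap of isopropylamino for isopropoxy and, read backwards, points to a small lower number. Nothing measured covers the difference between isopropoxy and isobutoxy. The expected step is therefore a 1.4-fold lower number from compound 3 to compound 4 (0.15 log units; within the scatter), not beyond the scatter. For compound 4 the expected value is 70 nM, with a range from 30 nM to 160 nM.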

Compound 4, half-maximal inhibitory concentration: 70 nM
Compound 4: middle estimate and measured number agree at the digits printed; the measured number falls inside the stated range.
By their numbers in this assay, from the lowest: compounds 2, 4 and 3 (each within the scatter of the next); then compound 1.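

In this assay, among the compounds shown here, isobutyl in place of isopropyl on the oxygen next to the carbonyl group gives no separable change at this position (a 1.2-fold higher number from compound 2 to compound 4 (0.07 log units; within the scatter)), a comparison the earlier compounds did not offer. Isobutoxy in place of isopropylamino on the carbonyl carbon is likewise unresolved (a 1.4-fold lower number from compound 3 to compound 4 (0.15 log units; within the scatter)), even though the leaving group carries a hydrogen-bond donor and the entering group carries none. The isobutoxy compound also stands clear of the 4-aminophenyl amide (a 3.1-fold lower number from compound 1 to compound 4 (0.50 log units; beyond the scatter)), so all three non-aryl groups shown on this carbonyl carbon now give a lower number than compound 1.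

Going by these compounds, whether a longer chain such as hexyloxy, a cyclic amine such as morpholine or a chain ending in a carboxylic acid would move the number beyond the scatter remains open. No measurement at hand accounts for the differences seen in this series.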